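From trifluoromethyl to ethoxycarbonyl: working notes on compound 4

The source may report more compounds than this note shows. Statements on the series, on what has been measured and on what is new or still open speak of the compounds shown alone.

Measured in a functional assay on HCT-116 cells (Homo sapiens) for antiproliferative activity, with a stated time of 48 h; on this read-out lower numbers stand for stronger inhibition and higher numbers for weaker inhibition
- compound 1 `CCN(CC)c1ccc(-c2cccc(Cl)c2)nn1` gives > 25000 nM as a limit
- compound 2 `CCN(CC)c1ccc(-c2cccc(C(F)(F)F)c2)nn1` gives > 25000 nM as a limit
- compound 3 `CCN(CC)c1ccc(-c2ccc(C(=O)OC)cc2)nn1` gives 60 nM as a number

Compound 2 stands at > 25000 nM which is a limit of the assay and not a number. Compound 4 `CCOC(=O)c1cccc(-c2ccc(N(CC)CC)nn2)c1` is still unmeasured. The change is ethoxycarbonyl in place of trifluoromethyl on an aromatic carbon and amounts to ethoxycarbonyl in place of trifluoromethyl on an aromatic carbon. Compound 1 and compound 2 share the limit of > 25000 nM in this assay, at which 2 of the 3 values shown sit, and so the step that the two limits leave unreadable from compound 1 to compound 2 lends no size to this change. Among the measured compounds shown here, the only numeric guide is compound 3 at 60 nM in this assay as the sole ester so far, though no measured step links it to compound 4. A move toward stronger inhibition is therefore expected, with a real chance that the result stays a limit. The expected change is an at least 5.0-fold lower number from compound 2 to compound 4 (0.69 log units; beyond the scatter) in this assay on this thin basis. Compound 4 is estimated at 5000 nM with an expected span from 300 nM to 25000 nM as its range.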

Compound 4, half-maximal inhibitory concentration: > 25000 nM
Compound 4 ended at the assay's limit (the forecaster's own chance of this, stated with the estimate: 40%); middle value at least 5.0-fold (0.69 log units) away from the limit.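

In this assay compound 4 gives > 25000 nM, which is a limit and not a number. The steps to compound 4 from compound 1 and compound 2 cannot be read, because all three sit at the same limit: the limit of > 25000 nM in this assay, at which 3 of the 4 values shown sit.

The compounds shown leave open how large the change to ethoxycarbonyl from chloro or trifluoromethyl actually is.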